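The source may report more compounds than this note shows. Statements on the series, on what has been measured and on what is new or still open speak of the compounds shown alone.

Measured so far, in an ADME assay on microsomes from liver (Mus musculus, strain Balb/c) for metabolic stability, read by LC-MS, with a stated time of 30 min, tested at 10 uM; a lower number here means that less of the compound is left, a higher number that more of the compound is left:
compound 1 `CS(=O)(=O)N1CCCN(S(=O)(=O)c2ccc(CN)s2)CC1` gives 37%;
compound 2 `CS(=O)(=O)c1ccc(S(=O)(=O)c2ccc(CN)s2)cc1` gives 67%;
compound 3 `CC(=O)NCCS(=O)(=O)c1ccc(S(=O)(=O)c2ccc(CN)s2)cc1` gives 91%.

Compound 2 stands second highest of the three. Compound 3 lies above it by a number 24 percentage points higher from compound 2 to compound 3 (beyond the scatter), and compound 1 lies below it, as the two values show. Compound 4 `Cn1cc(-c2cc(S(=O)(=O)c3ccc(CN)s3)ccc2S(C)(=O)=O)cn1` arises from compound 2 by 1-methyl-1H-pyrazol-4-yl in place of hydrogen on an aromatic carbon. Among the compounds with values here, the only measured step, the one from compound 2 to compound 3, also adds a group to compound 2 and raised the remaining fraction, but at a different place and with a different group, so it bears on the new change only loosely. A small rise, or no change beyond the scatter, is therefore expected in this assay: for compound 4 the estimate is 72%, within 50% to 90%, a step of a number 5 percentage points higher from compound 2 to compound 4 (within the scatter).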

Compound 4, percent of the compound remaining: 90%
Estimate against measurement, compound 4: 18 percentage points below; the range from low to high includes it.
By their numbers in this assay, from the lowest: compound 1; then compound 2; then compounds 4 and 3 (each within the scatter of the next).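

Putting 1-methyl-1H-pyrazol-4-yl in place of hydrogen on an aromatic carbon, ortho to the methylsulfonyl group, gives in this assay a number 23 percentage points higher from compound 2 to compound 4 (beyond the scatter). The earlier step changed a saturated chain carbon, whereas this one shows that a change on the aromatic ring can also leave more of the compound. No measurement at hand gives a reason for this rise. Going by these compounds, whether the rise needs this particular ring stays open. A methyl group, a phenyl ring or an amine on the same carbon could give a different number.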